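Para-substituent exchange on the piperidinyl benzoate series

The source may report more compounds than this note shows. Statements on the series, on what has been measured and on what is new or still open speak of the compounds shown alone.

The series is scored in a functional assay on the whole organism with Mus musculus as the target; on this read-out higher numbers stand for higher potency (the scale is a negative logarithm) and lower numbers for lower potency. Compound 1 `CN1CCC(OC(=O)c2ccc(Cl)cc2)CC1` stands highest of the two numbers recorded so far; in this assay compound 1 gives 1.11. Its nearest neighbour, compound 2 `COc1cccc(OC)c1C(=O)OC1CCN(C)CC1`, gives 0.63, a number that lies lower by a gap beyond the scatter. Compound 2 differs from compound 1 in more than one place, so the two values only show that the dimethoxy-substituted ester sits below the chloro-substituted one.

Compound 3 `CN1CCC(OC(=O)c2ccc(C#N)cc2)CC1` is the next member awaiting measurement. It differs from compound 1 by cyano in place of chloro on an aromatic carbon. For the measured compounds named here, no step that isolates this change between measured compounds is available, so nothing in the numbers shows whether it helps or harms. With the series resting on a single pair, the most that can be said is that no step beyond the scatter in either direction is anticipated; any drift is expected to be small and, if anything, downward, giving a step of a number 0.21 log units lower from compound 1 to compound 3 (within the scatter) expected from the change. On that basis compound 3 is estimated at 0.9, within a range from 0.3 to 1.5.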

Compound 3, logarithm of the reciprocal of the active concentration, log(1/C): 1.65
The estimate for compound 3 lay 0.75 log units below the measured number, and the stated range ends below it.
By their numbers in this assay, from the lowest: compound 2; then compound 1; then compound 3.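

In this assay, for the compounds shown here, cyano in place of chloro on an aromatic carbon, para to a large group, is the first change that can be read on its own, and it gives a number 0.54 log units higher from compound 1 to compound 3 (beyond the scatter) as a step beyond the scatter. This position therefore does not tolerate exchange silently: the number moves with the group it carries, and here the entering cyano, with its triple bond and hydrogen-bond acceptor, goes with the higher value. Nothing measured on these compounds accounts for the step, so the reading stays at the level of the exchange itself.

The compounds shown leave open whether the rise belongs to cyano alone or would also appear with another group at this position, such as trifluoromethyl, an amine, a carboxylic acid or a longer chain. They also leave open whether cyano would give a similar step on another substitution pattern, since compound 2 differs from the others in more than one place and offers no comparison of this kind.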